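Swapping methoxy for fluoro on a bithiophene amidine

This account rests on a few compounds, and the source may have more. Where it says the series, first, only, none or still open, it means among the compounds named here.

Measured so far:
compound 1 `COc1ccc(-c2ccc(-c3ccc(C(=N)N)s3)s2)cc1` gives 12900 nM
compound 2 `N=C(N)c1ccc(-c2ccc(-c3ccccc3)o2)o1` gives 68700 nM

Both numbers come from an ADME assay on WI-38 cells (Homo sapiens) for cytotoxicity, read by MTT assay, with a stated time of 48 h; a lower number here means a stronger inhibitor, a higher number a weaker inhibitor. Compound 1 has the lowest of the two numbers; compound 2 sits at a higher value, and the gap between them is beyond the usual scatter of this assay. Among the measured compounds shown here, no single-point step between measured compounds is available here, since compound 1 and compound 2 differ in more than one place, so what the two values show is only that compound 1 is the stronger inhibitor of the pair.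

The next compound, compound 3 `N=C(N)c1ccc(-c2ccc(-c3ccc(F)cc3)s2)s1`, is reached from compound 1 by one change: fluoro in place of methoxy on an aromatic carbon. The ring position is kept; only the group on it changes, with fewer heavy atoms and one fewer hydrogen-bond acceptor after the change.

For the measured compounds named here, with no measured step of this kind to lean on, the expected step from compound 1 to compound 3 is a 1.2-fold higher number from compound 1 to compound 3 (0.07 log units; within the scatter), small and within the usual scatter, with no clear direction. Compound 3 is therefore estimated at 15000 nM, with a range from 6000 nM to 40000 nM.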

Compound 3, half-maximal inhibitory concentration: 13300 nM
Compound 3: the middle estimate sits 1.1-fold (0.05 log units) above what was measured; the measured number falls inside the stated range.
By their numbers in this assay, from the lowest: compounds 1 and 3 (each within the scatter of the next); then compound 2.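

Among the compounds shown here, replacing methoxy with fluoro gives a 1.0-fold higher number from compound 1 to compound 3 (0.01 log units; within the scatter) in this assay, the first comparison here in which only one place differs. On a six-membered aromatic ring of carbon only, para to a large group, the two groups therefore cannot be told apart by this measurement, even though the change removes one heavy atom and one hydrogen-bond acceptor. For this pair, neither that acceptor nor the larger size of methoxy leaves a mark on the number beyond the usual scatter, and nothing measured here offers an explanation for that.

As far as these compounds go, one pair cannot show whether the same position would tolerate every group, so it remains open whether an amine, a carboxylic acid or a longer chain placed there would also leave the number within the scatter. Compound 2 differs from both compound 1 and compound 3 in more than one place, so it cannot yet show which single structural change matters for this cytotoxicity reading.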